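The compounds below may be only part of what the source reports. "The series", "measured", "known", "first", "only" and "open" are said of these compounds alone.

Measured in an ADME assay on HOS cells (Homo sapiens) for cytotoxicity; a lower number here means that less compound is tolerated, a higher number that more compound is tolerated:
- compound 1 `CCN1CCN(c2cccc3nc(CN(C)[C@H]4CCCc5cccnc54)cn23)CC1`: 3900 nM
- compound 2 `CCCN(Cc1cn2c(N3CCN(C)CC3)cccc2n1)[C@H]1CCCc2cccnc21`: 6700 nM
- compound 3 `CNCCN(C)c1cccc2nc(CN(C)[C@H]3CCCc4cccnc43)cn12`: 2200 nM

Compound 2 at 6700 nM lies within the scatter of compound 1 and beyond the scatter above compound 3. Compound 4 `CC(C)N(Cc1cn2c(N3CCN(C)CC3)cccc2n1)[C@H]1CCCc2cccnc21` has isopropyl in place of propyl on an amine nitrogen. Among the measured compounds shown here, no measured step covers a change at this place. The only one, a 1.8-fold lower number from compound 1 to compound 3 (0.25 log units; within the scatter), is on an aromatic carbon and stays within the scatter, so it gives only weak guidance. In this assay no shift beyond the scatter is expected. The expected step is a 1.2-fold lower number from compound 2 to compound 4 (0.09 log units; within the scatter). The estimate for compound 4 is 5500 nM, with an expected range of 2600 nM to 11000 nM.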

Compound 4, half-maximal cytotoxic concentration: 8900 nM
The estimate for compound 4 lay 1.6-fold (0.21 log units) below the measured number; low and high end bracket the measured number.
By their numbers in this assay, from the lowest: compounds 3, 1, 2 and 4 (each within the scatter of the next, the first and the last beyond it).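

On the amine nitrogen whose other neighbours are a saturated chain carbon and a saturated ring carbon, the first step read at this place in this assay is isopropyl in place of propyl, giving a 1.3-fold higher number from compound 2 to compound 4 (0.12 log units; within the scatter) with no change in heavy-atom count. The same three carbons can therefore be joined differently here without a shift beyond the scatter. Nothing on hand gives a cause for this step.

As far as these compounds go, whether a longer chain such as butyl, a cyclopropyl ring or a plain hydrogen on this nitrogen would give a shift beyond the scatter remains open. From the compounds shown here alone, whether this step holds with another group on the core also remains open.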